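The source may report more compounds than this note shows. Statements on the series, on what has been measured and on what is new or still open speak of the compounds shown alone.

Measured compounds:
compound 1 `COc1ccc2[nH]c(C(=O)N[C@H](CCCNC(=N)N)C(=O)NCc3ccc(C(F)(F)F)cc3)cc2c1` — 78 nM
compound 2 `N=C(N)NCCC[C@@H](NC(=O)c1cc2ccccc2cn1)C(=O)NCc1ccc(C(F)(F)F)cc1` — 1810 nM

The series is followed in a functional assay on HEK293 cells for antagonist activity at melanin-concentrating hormone receptor 1 (Homo sapiens); on this read-out higher numbers stand for weaker inhibition and lower numbers for stronger inhibition. Among the two measured compounds, compound 1 gives the lowest number, and its nearest neighbour is compound 2, which is set apart from it by a 23-fold higher number from compound 1 to compound 2 (1.37 log units; beyond the scatter). Among the compounds with values here, that step exchanges one bicyclic aromatic group for another on the carbonyl carbon and is the only measured change available for comparison.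

Compound 3 `N=C(N)NCCC[C@@H](NC(=O)c1ccnc2ccccc12)C(=O)NCc1ccc(C(F)(F)F)cc1` has not yet been measured. It differs from compound 1 in a single place: quinolin-4-yl in place of 5-methoxy-1H-indol-2-yl on a carbonyl carbon. As in the step to compound 2, the bicyclic group with its hydrogen-bond donor leaves and a nitrogen-containing bicyclic ring without a donor enters. Because a 23-fold higher number from compound 1 to compound 2 (1.37 log units; beyond the scatter) was large, a loss of similar size is expected here, so that this assay for compound 3 is expected to show a 19-fold higher number from compound 1 to compound 3 (1.28 log units; beyond the scatter). For compound 3 the expected value is therefore 1500 nM, with a range from 300 nM to 7000 nM.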

Compound 3, half-maximal inhibitory concentration: 1030 nM
For compound 3 the middle estimate is 1.5-fold (0.16 log units) above the measured one; measured number inside the range.
By their numbers in this assay, from the lowest: compound 1; then compounds 3 and 2 (each within the scatter of the next).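

In this assay, a second replacement of the 5-methoxy-1H-indol-2-yl group on the carbonyl carbon gives a 13-fold higher number from compound 1 to compound 3 (1.12 log units; beyond the scatter), so the large change seen with isoquinolin-3-yl is not confined to that one group. Quinolin-4-yl and isoquinolin-3-yl are not told apart in this assay, with a 1.8-fold lower number from compound 2 to compound 3 (0.24 log units; within the scatter). Among these three compounds, only the 5-methoxy-1H-indol-2-yl group stands clear of the others, and both groups without a hydrogen-bond donor end up together.

Nothing available explains what lies behind these differences. Going by these compounds, each replacement changes the ring size, the hydrogen-bond donor and the methoxy oxygen together, so which of these matters stays open; an unsubstituted 1H-indol-2-yl group or a 5-methoxy-1-methyl-1H-indol-2-yl group would separate them.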